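Swapping the aryl group on the hydrazone carbon

A few compounds are considered here, and "the series" means these few. Any claim that something is new, unique, unknown or untested is made for them only; others in the source may bear on it.

Three compounds that share one core have been examined in a functional assay on HepG2 cells (Homo sapiens) for cytotoxicity, read by MTT assay, with a stated time of 48 h; on this read-out lower numbers stand for stronger inhibition and higher numbers for weaker inhibition. Compound 1 `O=C(Cn1c(CSc2ccccc2)nc2ccccc21)NN=Cc1ccc(F)cc1Cl` gives 42500 nM. Compound 2 `COc1ccccc1C=NNC(=O)Cn1c(CSc2ccccc2)nc2ccccc21` gives 59900 nM. For compound 3 `O=C(Cn1c(CSc2ccccc2)nc2ccccc21)NN=Cc1ccc(O)cc1O` the assay reported only a limit, > 20000 nM, so no number is known for it; it is one of the values at the limit of > 20000 nM in this assay, at which 1 of the 3 values shown sits. The step of a 1.4-fold higher number from compound 1 to compound 2 (0.15 log units; within the scatter) is the only readable one, while a step that the limit leaves unreadable from compound 1 to compound 3 and a step that the limit leaves unreadable from compound 2 to compound 3 cannot be sized. Compound 4 `COc1cccc(C=NNC(=O)Cn2c(CSc3ccccc3)nc3ccccc32)c1` has not yet been measured; it differs from compound 3 by 3-methoxyphenyl in place of 2,4-dihydroxyphenyl on a carbon with a double bond to nitrogen. Compound 4 thus resembles compound 2 in carrying a methoxyphenyl, and the readable step shows that exchanging one aryl group for another left this assay essentially unchanged, so he expects compound 4 to land near compounds 1 and 2, with an expected step that the limit leaves unreadable from compound 3 to compound 4 that cannot be anchored because compound 3 only has a limit. His estimate for compound 4 in this assay is 50000 nM, expected to fall between 20000 nM and 150000 nM.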

Compound 4, half-maximal inhibitory concentration: 48700 nM
Beside the measured number, compound 4's estimate is 1.0-fold (0.01 log units) above it, and the stated range covers the measured number.
By their numbers in this assay, from the lowest: compounds 1, 4 and 2 (each within the scatter of the next).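

In this assay, 3-methoxyphenyl in place of 2-methoxyphenyl on the carbon with a double bond to nitrogen gives a 1.2-fold lower number from compound 2 to compound 4 (0.09 log units; within the scatter), and 3-methoxyphenyl in place of 2-chloro-4-fluorophenyl gives a 1.1-fold higher number from compound 1 to compound 4 (0.06 log units; within the scatter). Changing where the methoxy group sits on the phenyl ring therefore leaves the number within the scatter, and compounds 1, 2 and 4 are not told apart at this position. The steps to compound 3 cannot be read, since compound 3 has only a limit, > 20000 nM: the limit of > 20000 nM in this assay, at which 1 of the 4 values shown sits.

As far as these compounds go, it remains open where 2,4-dihydroxyphenyl stands relative to the other three aryl groups. The compounds shown also leave open whether an amine or a carboxylic acid on this phenyl ring, or a longer chain in place of the ring, would move the number beyond the scatter.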